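Indolyl quinazoline series: Vero antiproliferation notes

The compounds below may be only part of what the source reports. "The series", "measured", "known", "first", "only" and "open" are said of these compounds alone.

Measured so far:
compound 1 `c1ccc2c(c1)ccn2-c1nc(N2CCCCC2)nc2ccccc12` 50 ug/mL
compound 2 `CN1CCN(c2nc(-c3cn(C)c4ccccc34)c3ccccc3n2)CC1` 50 ug/mL
compound 3 `CN1CCN(c2nc(-n3ccc4ccccc43)c3ccccc3n2)CC1` 22.3 ug/mL

In an ADME assay on Vero cells (Chlorocebus sabaeus) for antiproliferative activity, read by MTT assay (on this read-out lower numbers stand for stronger inhibition and higher numbers for weaker inhibition), compound 3 stands at the lowest of the three numbers; compound 1 and compound 2 share the same higher value. Among the measured compounds shown here, the only single-point step is a 2.2-fold lower number from compound 1 to compound 3 (0.35 log units; beyond the scatter). Compound 4 `Fc1ccc(N2CCN(c3nc(-n4ccc5ccccc54)c4ccccc4n3)CC2)cc1` is compound 3 with 4-fluorophenyl in place of methyl on an amine nitrogen in a ring. For the measured compounds named here, no measured step touches the substituent on this ring nitrogen, so that step gives no direct guide, and the observed spread across the three compounds is narrow. The expected step in this assay is therefore a 1.3-fold higher number from compound 3 to compound 4 (0.13 log units; within the scatter), a change not clearly beyond the scatter in either direction. Compound 4 is estimated at 30 ug/mL, expected between 12 ug/mL and 65 ug/mL.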

Compound 4, half-maximal inhibitory concentration: 50 ug/mL
Compound 4: the middle estimate sits 1.7-fold (0.22 log units) below what was measured; measured number inside the range.
By their numbers in this assay, from the lowest: compound 3; then compounds 1, 2 and 4 (each within the scatter of the next).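

In this assay, the substituent on the ring amine nitrogen affects the read-out: a 2.2-fold higher number from compound 3 to compound 4 (0.35 log units; beyond the scatter), a modest step towards weaker inhibition with 4-fluorophenyl in place of methyl. Among the compounds shown here, this is the first measured change at this nitrogen, and the larger aromatic group does not retain the value of compound 3. Nothing available accounts for this step.

From the compounds shown here alone, whether the step follows from the aromatic ring or from its fluorine remains open. An unsubstituted phenyl, a benzyl or an ethyl group on this nitrogen would help separate these possibilities.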